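Difluorophenyl in place of phenyl: estimate for compound 4

The compounds below may be only part of what the source reports. "The series", "measured", "known", "first", "only" and "open" are said of these compounds alone.

Measured so far in an in vitro assay on HEK385-7 cells for displacement of a labelled ligand from prostaglandin D2 receptor 2 (Homo sapiens); a higher number here means a weaker inhibitor, a lower number a stronger inhibitor:

compound 1 `O=C(O)Cc1sc(C(c2ccccc2)c2ccccc2)nc1-c1ccccc1` — 570 nM
compound 2 `O=C(O)Cc1sc(C(c2ccc(F)cc2)c2ccc(F)cc2)nc1-c1ccccc1` — 16 nM
compound 3 `COc1cc(-c2nc(C(c3ccc(F)cc3)c3ccc(F)cc3)sc2CC(=O)O)ccn1` — 29 nM

Compound 1 gives the highest number of the three. Its nearest neighbour is compound 3, a gap beyond the scatter; compound 2 stands further off, also beyond the scatter. Within the data shown here, no single step joins compound 1 to compound 2 or to compound 3, so these pairs show only their two values.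

Compound 4 `O=C(O)Cc1sc(C(c2ccccc2)c2ccccc2)nc1-c1ccc(F)c(F)c1` is compound 1 changed at one place: 3,4-difluorophenyl in place of phenyl on an aromatic carbon. Among the measured compounds shown here, the one measured step at this same place on the shared core is a 1.8-fold higher number from compound 2 to compound 3 (0.26 log units; within the scatter), which stays within the scatter. That step exchanged the whole ring for a heteroaryl rather than adding fluorine, so direct precedent for the present change is lacking. On this basis a step no larger than the scatter, or a modest one in either direction, is expected in this assay for compound 4. Compound 4 is therefore estimated at 350 nM, with a range of 120 nM to 1000 nM. This estimate means an expected step of a 1.6-fold lower number from compound 1 to compound 4 (0.21 log units; within the scatter), with the uncertainty weighted toward a lower number only because compound 3 at 29 nM shows that changes at this place need not cost anything.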

Compound 4, half-maximal inhibitory concentration: 4.1 nM
The estimate for compound 4 lay 85-fold (1.93 log units) above the measured number; the whole stated range lies above it.
By their numbers in this assay, from the lowest: compound 4; then compounds 2 and 3 (each within the scatter of the next); then compound 1.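

In this assay, the group on the aromatic carbon next to the ring nitrogen emerges as a strong lever on the number: 3,4-difluorophenyl in place of phenyl gives a large step (a 140-fold lower number from compound 1 to compound 4 (2.14 log units; beyond the scatter)). Among these compounds, the only earlier step at this place (a 1.8-fold higher number from compound 2 to compound 3 (0.26 log units; within the scatter)) stayed within the scatter, so the position is now seen to respond strongly to at least one change, although that earlier step exchanged the ring for 2-methoxypyridin-4-yl and began from compound 2, not compound 1. Nothing at hand accounts for the size of the new step.

The compounds shown leave open whether one fluorine alone would carry the step, as 3-fluorophenyl or 4-fluorophenyl at this place would show, and whether 3,4-dichlorophenyl would behave alike. They also leave open whether 3,4-difluorophenyl gives a step of similar size on the core of compound 2.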